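A Methoxy Step Repeated on a Second Core

A few compounds are considered here, and "the series" means these few. Any claim that something is new, unique, unknown or untested is made for them only; others in the source may bear on it.

Compound 1 `COc1ccc(-c2cc(/C=C/C(=O)c3ccc(N)cc3)[nH]n2)cc1` and compound 3 `COc1ccc(-c2cc(/C=C/C(=O)c3ccc(N)cc3)[nH]n2)cc1OC` share one core and differ by a single change, (methoxy in place of hydrogen on an aromatic carbon). In a functional assay on A498 cells (Homo sapiens) for inhibition, read by sulforhodamine B assay, with a stated time of 48 h (on this read-out lower numbers stand for stronger inhibition of growth and higher numbers for weaker inhibition of growth), compound 1 gives 4950 nM and compound 3 gives 7090 nM; the measured step is a 1.4-fold higher number from compound 1 to compound 3 (0.16 log units; within the scatter). Compound 2 `COc1ccc(C(=O)/C=C/c2cc(-c3cc(OC)c(OC)c(OC)c3)n[nH]2)cc1OC` rests on a core whose difference from compound 1 is not broken down here. In this assay compound 2 gives 2980 nM, the lowest of the three numbers, within the scatter of compound 1 and beyond the scatter only against compound 3. Compound 4 `COc1cc(C(=O)/C=C/c2cc(-c3cc(OC)c(OC)c(OC)c3)n[nH]2)cc(OC)c1OC` has not yet been measured; it differs from compound 2 by methoxy in place of hydrogen on an aromatic carbon. This is the same kind of change as that from compound 1 to compound 3, though the place is not identical: in compound 4 the entering methoxy is also meta to a methoxy group, which is not so in compound 3. Because the measured instance a 1.4-fold higher number from compound 1 to compound 3 (0.16 log units; within the scatter) stayed within the scatter, a step of similar size is expected here: a 1.3-fold higher number from compound 2 to compound 4 (0.13 log units; within the scatter). Compound 4 is therefore estimated at 4000 nM in this assay, with a range from 1500 nM to 10000 nM.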

Compound 4, concentration for total growth inhibition: 3590 nM
Compound 4: the middle estimate sits 1.1-fold (0.05 log units) above what was measured, and the stated range covers the measured number.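

In this assay, the new step is a 1.2-fold higher number from compound 2 to compound 4 (0.08 log units; within the scatter). Set beside the earlier step, the methoxy change carries from one core to the other with no gap that can be told from the scatter: the same change on two cores in this assay, a 1.4-fold higher number (0.16 log units; within the scatter) from compound 1 to compound 3 and a 1.2-fold higher number (0.08 log units; within the scatter) from compound 2 to compound 4, 1.2-fold (0.08 log units) apart, within the scatter of two such steps. For the compounds shown here, this shows only that on these two cores, with one pair of compounds on each and the entering methoxy at places that are not identical, the step stays within the scatter; it does not show that the change would behave alike on a further core or at another place on the ring, and steps this small give no ground for saying what the methoxy group does in these cells.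

The compounds shown leave open whether a group other than methoxy at this place, such as a hydroxyl, an amine or a longer alkoxy chain, would give a step beyond the scatter. They also leave open whether the same methoxy change would give a step of this size on other cell lines.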